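The compounds below may be only part of what the source reports. "The series", "measured", "known", "first", "only" and "open" are said of these compounds alone.

Measured so far:
- compound 1, `O=C(N/N=C/c1ccccc1)c1cnccn1`, 75% in an ADME assay on J774 cells (Mus musculus) for cytotoxicity, read by MTT assay, with a stated time of 48 h, tested at 100 ug/mL; on this read-out higher numbers stand for a weaker effect at the one concentration tested and lower numbers for a stronger effect
- compound 2, `O=C(N/N=C/c1ccccc1Br)c1cnccn1`, 100% in this assay

Compound 2 gives the highest of the two numbers; its nearest neighbour is compound 1, and the step of a number 25 percentage points higher from compound 1 to compound 2 (beyond the scatter) lies beyond the scatter. Compound 3, `COc1ccccc1/C=N/NC(=O)c1cnccn1`, has not yet been measured in this assay. It differs from compound 2 in one place: methoxy in place of bromo on an aromatic carbon. For the measured compounds named here, the only measured step, bromo in place of hydrogen, raised the number from compound 1 to compound 2; no measured step compares methoxy with bromo, so the direction of the change to compound 3 is uncertain. Given that compound 2 sits at the top of the scale with 100%, the expected step of a number 15 percentage points lower from compound 2 to compound 3 (beyond the scatter) is downward, and compound 3 is estimated at 85% in this assay, with a range from 60% to 100%.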

Compound 3, a percentage reported as activity, at one concentration (the size of the read-out at that concentration, not a potency): 100%
Estimate against measurement, compound 3: 15 percentage points below; the measured number falls inside the stated range.
By their numbers in this assay, from the lowest: compound 1; then compounds 2 and 3 (each within the scatter of the next).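

In this assay, on this aromatic carbon ortho to a large group, methoxy in place of bromo gives no change at the digits printed from compound 2 to compound 3 (within the scatter), even though methoxy brings a hydrogen-bond acceptor and bromo does not. Methoxy in place of hydrogen gives a number 25 percentage points higher from compound 1 to compound 3 (beyond the scatter), the same size as the step of a number 25 percentage points higher from compound 1 to compound 2 (beyond the scatter), so the difference from compound 1 no longer rests on bromo alone. Nothing available explains why these two groups give matching numbers.

On these data alone, whether an amine or a carboxylic acid on this same carbon would also give a number in line with compound 2 and compound 3 remains open. So does whether bromo or methoxy would behave the same way on another carbon of the ring, and a single concentration cannot separate these compounds by potency.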